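A few compounds are considered here, and "the series" means these few. Any claim that something is new, unique, unknown or untested is made for them only; others in the source may bear on it.

Measured so far in a functional assay on OVCAR-8 cells (Homo sapiens) for inhibition, read by sulforhodamine B assay, with a stated time of 48 h; on this read-out higher numbers stand for weaker inhibition of growth and lower numbers for stronger inhibition of growth:
Compound 1, `COc1cc(-c2cc(/C=C/C(=O)c3ccc(N)cc3)[nH]n2)cc(OC)c1OC`: 2390 nM
Compound 2, `COc1ccc(-c2cc(/C=C/C(=O)c3ccc(OC)c(OC)c3)[nH]n2)cc1`: 2160 nM
Compound 3, `COc1cc(-c2cc(/C=C/C(=O)c3ccc(Cl)c(Cl)c3)[nH]n2)cc(OC)c1OC`: 6300 nM

Compound 1 gives the second highest of the three numbers. Its nearest neighbour is compound 2, whose value lies within the scatter of that of compound 1. Among the compounds with values here, the only recorded single-point step is a 2.6-fold higher number from compound 1 to compound 3 (0.42 log units; beyond the scatter), a modest rise that comes from a change on the carbonyl side of the shared core, where a 3,4-dichlorophenyl stands in place of the 4-aminophenyl.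

Compound 4, `COc1ccc(-c2cc(/C=C/C(=O)c3ccc(N)cc3)[nH]n2)cc1OC`, has not yet been measured in this assay. Relative to compound 1 it differs in one place: hydrogen in place of methoxy on an aromatic carbon. The change sits on the ring attached to the other end of the shared core, not on the carbonyl aryl. Within the data shown here, no measured step touches this ring; the step from compound 1 to compound 3 alters the carbonyl aryl instead, and compound 2 differs from compound 1 in more than one place, so its value shows only that a differently substituted pair of rings lands within the scatter of compound 1. Nothing here supports a shift beyond the scatter in either direction. The expected step of a 1.0-fold higher number from compound 1 to compound 4 (0.02 log units; within the scatter) is small. Compound 4 is accordingly estimated at 2500 nM, with a range from 1000 nM to 6500 nM.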

Compound 4, concentration for 50% growth inhibition: 2950 nM
The estimate for compound 4 lay 1.2-fold (0.07 log units) below the measured number; the measured number falls inside the stated range.
By their numbers in this assay, from the lowest: compounds 2, 1 and 4 (each within the scatter of the next); then compound 3.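

In this assay, within the data shown here, the first reading on the ring at the far end of the shared core from the carbonyl is a 1.2-fold higher number from compound 1 to compound 4 (0.09 log units; within the scatter), with hydrogen in place of methoxy on an aromatic carbon. Among these compounds, at this position, ortho to a methoxy group and meta to a large group, the methoxy can therefore be exchanged for hydrogen without a change that can be told from the scatter, whereas the only earlier single-place step, made on the carbonyl aryl, is a 2.6-fold higher number from compound 1 to compound 3 (0.42 log units; beyond the scatter) and lies beyond it. No supporting measurement bears on this result, so the notes offer only the size of the step and no account of it.

Among the compounds shown here, still open is whether a hydroxyl, a chlorine or a longer ethoxy chain at this position would also stay within the scatter of compound 1, since hydrogen and methoxy are the only two groups compared here. On these data alone, it is also open whether the same exchange would read alike with 3,4-dichlorophenyl on the carbonyl in place of 4-aminophenyl, and whether a change at either of the remaining methoxy groups on this ring would be equally small.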